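The compounds below may be only part of what the source reports. "The series", "measured", "known", "first", "only" and "open" are said of these compounds alone.

Compound 2, whose structure is `O=C(NNc1cccc2ncccc12)C1(c2ccccc2F)CCCCC1`, gives 324 nM in an in vitro functional assay on 1321-N1 cells for antagonist activity at P2X purinoceptor 7 (Rattus norvegicus), read by FLIPR and calcium flux; on this read-out higher numbers stand for weaker inhibition and lower numbers for stronger inhibition. Going by the values given here, of the two compounds measured so far it carries the higher number, which on this read-out means the weaker inhibition. Among the compounds with values here, its only neighbour is compound 1, with the structure `COc1ccc(C2(C(=O)NNc3cccc4ncccc34)CCCCC2)cc1`, which gives 51.3 nM in this assay; the single measured step, a 6.3-fold higher number from compound 1 to compound 2 (0.80 log units; beyond the scatter), exchanged one aromatic group for another on the saturated ring carbon.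

Compound 3, with the structure `O=C(NNc1cccc2ncccc12)C1(c2cccc(F)c2)CCCCC1`, has not yet been measured. It differs from compound 2 only in this: 3-fluorophenyl in place of 2-fluorophenyl on a saturated ring carbon. Within the data shown here, no measured pair shows what moving the fluorine around the ring does; the step from compound 1 to compound 2 concerned a different group altogether, so it bears on compound 3 only loosely, as a sign that swapping the aromatic group at this position can shift the number modestly. For compound 3 the expectation is therefore a small shift in this assay, likely within the scatter of compound 2, summed up as a 1.6-fold lower number from compound 2 to compound 3 (0.21 log units; within the scatter). The estimated value for compound 3 is 200 nM, with a range from 60 nM to 700 nM.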

Compound 3, half-maximal inhibitory concentration: 257 nM
The estimate for compound 3 lay 1.3-fold (0.11 log units) below the measured number; the range from low to high includes it.
By their numbers in this assay, from the lowest: compound 1; then compounds 3 and 2 (each within the scatter of the next).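

In this assay, moving the fluorine while keeping the fluorophenyl group on the same saturated ring carbon gives a 1.3-fold lower number from compound 2 to compound 3 (0.10 log units; within the scatter), so this pair, the first to change only where the fluorine sits, does not separate 2-fluorophenyl from 3-fluorophenyl. The 4-methoxyphenyl group of compound 1 stays apart from both fluorinated groups: the change to 3-fluorophenyl gives a 5.0-fold higher number from compound 1 to compound 3 (0.70 log units; beyond the scatter), and this step lies beyond the scatter, as does a 6.3-fold higher number from compound 1 to compound 2 (0.80 log units; beyond the scatter), so the earlier difference is not confined to the 2-fluorophenyl group. Nothing available here explains any of these numbers.

The compounds shown leave open whether the lower number of compound 1 goes with the methoxy group itself or with its place on the aromatic ring, a question that 4-fluorophenyl and 3-methoxyphenyl groups on the same carbon could help to answer. They also leave open how a plain phenyl group, or a phenyl group carrying an amine or a carboxylic acid, would read in this assay on the shared core.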